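Fluorophenyl for methylphenyl on the sulfonyl of compound 1

The source may report more compounds than this note shows. Statements on the series, on what has been measured and on what is new or still open speak of the compounds shown alone.

Compound 1 `Cc1ccc(S(=O)(=O)Nc2ccc(-c3nc4ccccc4o3)cc2)cc1` was run in an assay on cells for inhibition of HSP60/HSP10 (Homo sapiens), with a stated time of 60 min; on this read-out lower numbers stand for stronger inhibition and higher numbers for weaker inhibition. In this assay compound 1 returns only a limit, > 100000 nM, and so stands at the limit of > 100000 nM in this assay, at which 2 of the 3 values shown sit. Compound 3 `O=S(=O)(Nc1ccc2oc(-c3ccccc3)nc2c1)c1ccccc1F` likewise returns only a limit in this assay, > 100000 nM. Among the measured compounds shown here, compound 2 `O=S(=O)(Nc1ccc(-c2nc3cc(NS(=O)(=O)c4cccs4)ccc3o2)cc1)c1cccs1`, carrying two thiophene sulfonamides, gives 40000 nM in this assay, the single number read so far. Compound 4 `O=S(=O)(Nc1ccc(-c2nc3ccccc3o2)cc1)c1ccccc1F` differs from compound 1 by 2-fluorophenyl in place of 4-methylphenyl on a sulfonyl sulfur. Compound 3 also carries a 2-fluorophenyl sulfonamide and stays at the limit. For the measured compounds named here, no measured step covers this change; the step of a number no higher from compound 1 to compound 4 (the limit leaves the size open) is expected to be none beyond the usual scatter. For compound 4 the estimate is 100000 nM, within 30000 nM to 300000 nM, with a limit rather than a number the likelier outcome.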

Compound 4, half-maximal inhibitory concentration: > 100000 nM
Compound 4: no number, only a limit (the forecaster's own chance of this, stated with the estimate: 70%); the middle value sits exactly at the limit.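

Compound 1 and compound 4 each return only a limit, so no step between them can be read: the limit of > 100000 nM in this assay, at which 3 of the 4 values shown sit.

From the compounds shown here alone, whether 2-fluorophenyl in place of 4-methylphenyl on a sulfonyl sulfur changes inhibition at all stays open.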